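The source may report more compounds than this note shows. Statements on the series, on what has been measured and on what is new or still open speak of the compounds shown alone.

Measured compounds:
compound 1 `Cn1cc(/C=C2/C(=O)Nc3ccccc32)c2cc(Nc3nccc(-c4ccccc4)n3)ccc21` — in an ADME assay on RWPE-1 cells (Homo sapiens) for cytotoxicity, read by MTT assay, with a stated time of 48 h (on this read-out higher numbers stand for weaker inhibition and lower numbers for stronger inhibition), compound 1 gives 95600 nM
compound 2 `Cc1ccc(-c2ccnc(Nc3ccc4c(c3)c(/C=C3/C(=O)Nc5ccccc53)cn4C)n2)cc1` — in this assay compound 2 gives "not determined" (no result reported)
compound 3 `COc1ccc(-c2ccnc(Nc3ccc4c(c3)c(/C=C3/C(=O)Nc5ccccc53)cn4C)n2)cc1` — in this assay compound 3 gives "not determined" (no result reported)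

Compound 3 therefore stands without a number in this assay; the only figure in the series belongs to compound 1, which sits at a weak level of cytotoxicity. Compound 4 `Cn1cc(/C=C2/C(=O)Nc3ccccc32)c2cc(Nc3nccc(-c4ccc(O)cc4)n3)ccc21` is the next entry. The change from compound 3 to compound 4 is hydrogen in place of methyl on an oxygen on an aromatic ring. Within the data shown here, with no measured pair showing such a change, no step can be computed for it, and nothing here says in which direction it would move. The expectation rests on compound 1 alone: compound 4 is expected to stay near the weak level seen there, with a wide margin. Compound 4 is expected at 80000 nM, in the range 25000 nM to 250000 nM.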

Compound 4, half-maximal inhibitory concentration: 58400 nM
Beside the measured number, compound 4's estimate is 1.4-fold (0.14 log units) above it; the measured number falls inside the stated range.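

In this assay, hydroxy in place of hydrogen on an aromatic carbon gives a 1.6-fold lower number from compound 1 to compound 4 (0.21 log units; within the scatter), so this position of the phenyl ring now has a second number, and the change does not separate from the scatter. Nothing available accounts for this result.

The steps to and from compounds 2 and 3 cannot be read, which leaves methoxy to hydroxy unresolved. On these data alone, how an amine or a carboxylic acid on that aromatic carbon would read in this assay also remains open.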